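Same Atoms, Joined Differently: A Question of Proton Release

A few compounds are considered here, and "the series" means these few. Any claim that something is new, unique, unknown or untested is made for them only; others in the source may bear on it.

Of the compounds shown here, three have been measured in a physicochemical assay for acid dissociation. Compound 2 `CC1CCN(C(=O)c2ccc3cc(OCCC4CCCN4C)ccc3c2)CC1` gives 9.9, the highest of the three numbers, although its lead is not beyond the usual scatter in every case. Compound 3 `CC1CCN(C(=O)c2ccc3cc(OCCCN4CCCCC4)ccc3n2)CC1`, at 9.7, lies within the scatter of compound 2. Compound 1 `CC(C)N1CCC(Oc2ccc3nc(C(=O)N4CCC4)ccc3c2)CC1`, at 9.5, sits lower than compound 2 by more than the scatter.

The next compound is compound 4 `CC1CCN(C(=O)c2ccc3cc(OC4CCN(C(C)C)C4)ccc3c2)CC1`. It has the same atoms as compound 2, joined differently: 1-isopropylpyrrolidin-3-yl in place of 2-(1-methylpyrrolidin-2-yl)ethyl on an oxygen on an aromatic ring. In words, 1-isopropylpyrrolidin-3-yl stands in place of 2-(1-methylpyrrolidin-2-yl)ethyl on an oxygen on an aromatic ring.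

Going by the values given here, no two measured compounds differ in one place only, so no measured step can serve as a guide. The closest reference is compound 1 at 9.5, which also carries an isopropyl group. A modest fall is expected, with the estimated step being a number 0.60 log units lower from compound 2 to compound 4 (beyond the scatter). For compound 4 the estimated value is 9.3, with an expected range from 8.9 to 9.7.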

Compound 4, acid dissociation constant: 9.4
Compound 4: the middle estimate sits 0.10 log units below what was measured, within the range that was stated.
By their numbers in this assay, from the lowest: compounds 4, 1, 3 and 2 (each within the scatter of the next, the first and the last beyond it).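

In this assay, going by these compounds alone, the result gives the first step at a single position, on an oxygen on an aromatic ring: 1-isopropylpyrrolidin-3-yl in place of 2-(1-methylpyrrolidin-2-yl)ethyl gives a number 0.50 log units lower from compound 2 to compound 4 (beyond the scatter). Within the data shown here, no earlier pair could show this, since no two of those compounds differed in one place only. The two groups have the same heavy-atom count, the same kind of ring and the same hydrogen-bond counts, so a step beyond the scatter can occur here with none of those counts changing.

From the compounds shown here alone, whether a 2-(morpholin-4-yl)ethyl group on the same oxygen would give a number nearer that of compound 2 or compound 4 remains open. Nothing in the data shown accounts for the size of this step.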